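The compounds below may be only part of what the source reports. "The series", "measured", "known", "first", "only" and "open" are said of these compounds alone.

Working notes on the series. Compound 1 `CC(Sc1nc2c(cnn2C)c(=O)n1-c1ccccc1)c1ccccn1` is examined in an assay on isolated protein for inhibition of retinal dehydrogenase 2 (Homo sapiens) (a higher number here means a weaker inhibitor, a lower number a stronger inhibitor), where compound 1 gives 63 nM. This is the lowest number shown, though compound 3 `CC(Sc1nc2nn(C3(C)COC3)cc2c(=O)n1-c1ccccc1)c1ccccc1`, with 112 nM in this assay, lies within the usual scatter of it. Compound 2 `Cn1ncc2c(=O)n(-c3ccccc3)c(/C=C/c3cccc(F)c3)nc21` gives 440 nM in this assay, beyond the scatter and thus a weaker inhibitor than compound 1.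

Compound 4 `CC(Sc1nc2c(cnn2C)c(=O)n1-c1ccccc1)c1cccc(F)c1` is not yet measured. It differs from compound 1 by 3-fluorophenyl in place of pyridin-2-yl on a saturated chain carbon bound to a saturated chain carbon and a sulfur. Within the data shown here, no measured pair shows this change directly; compound 3 carries a phenyl at the same place, on a differently substituted core, and gives 112 nM. A step from compound 1 to compound 4 of a 1.6-fold higher number from compound 1 to compound 4 (0.20 log units; within the scatter) is expected in this assay, within the scatter. For compound 4 the estimate in this assay is 100 nM, with a range from 35 nM to 300 nM.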

Compound 4, half-maximal inhibitory concentration: 110 nM
For compound 4 the middle estimate is 1.1-fold (0.04 log units) below the measured one, within the range that was stated.
By their numbers in this assay, from the lowest: compounds 1, 4 and 3 (each within the scatter of the next); then compound 2.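

In this assay, among these compounds, the first direct pair at this position gives a 1.7-fold higher number from compound 1 to compound 4 (0.24 log units; within the scatter) for 1-(pyridin-2-yl)ethyl to 1-(3-fluorophenyl)ethyl on the shared core. On this core, then, a carbon-only aromatic ring carrying fluorine can replace the ring with a hetero atom without a change beyond the scatter. Nothing available bears on the reason for this result.

On these data alone, what an amine or a carboxylic acid in place of 3-fluorophenyl at this position would give stays open. Also open, as far as these compounds go, is whether an unsubstituted phenyl on the core of compound 1 would read like 3-fluorophenyl.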